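This account rests on a few compounds, and the source may have more. Where it says the series, first, only, none or still open, it means among the compounds named here.

Compound 3, `CCCCC(O)[C@H](CC(C)C)NC(=O)[C@@H](NC(=O)[C@@H](NC(=O)OC(C)(C)C)C(C)C)C(C)C`, is one of three compounds of a shared core examined in an assay on isolated protein for inhibition of Pepsin A (Homo sapiens); on this read-out higher numbers stand for weaker inhibition and lower numbers for stronger inhibition. In this assay compound 3 gives 1240 nM. Compound 1, `CCCCCCC(O)[C@H](CCC)NC(=O)[C@@H](NC(=O)[C@@H](NC(=O)OC(C)(C)C)C(C)C)C(C)C`, gives 700 nM in this assay, and compound 2, `CCCCCCCCC(O)[C@H](CCC)NC(=O)[C@@H](NC(=O)[C@@H](NC(=O)OC(C)(C)C)C(C)C)C(C)C`, gives 1070 nM; the number for compound 3 stands within the usual scatter of both, so nothing separates the three on these numbers. Compound 4, `CCCCCCC(O)[C@H](CC(C)C)NC(=O)[C@@H](NC(=O)[C@@H](NC(=O)OC(C)(C)C)C(C)C)C(C)C`, differs from compound 3 by ethyl in place of hydrogen on a saturated chain carbon, five bonds along the chain from an oxygen on a saturated carbon. Among the measured compounds shown here, the only measured step that bears on this is the one from compound 1 to compound 2, which also puts an ethyl in place of a hydrogen on the same chain, though seven bonds along it: a 1.5-fold higher number from compound 1 to compound 2 (0.18 log units; within the scatter). On that basis no movement beyond the scatter is expected for compound 4 in this assay, and the step of a 1.3-fold lower number from compound 3 to compound 4 (0.12 log units; within the scatter) is the estimate. Compound 4 is therefore expected to give about 950 nM in this assay, within a range from 400 nM to 2200 nM.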

Compound 4, half-maximal inhibitory concentration: 830 nM
Compound 4: middle estimate off by 1.1-fold (0.06 log units), on the high side; the range from low to high includes it.
By their numbers in this assay, from the lowest: compounds 1, 4, 2 and 3 (each within the scatter of the next).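

In this assay, the change of ethyl in place of hydrogen on this saturated chain now has a second reading, five bonds along the chain from the oxygen on a saturated carbon: a 1.5-fold lower number from compound 3 to compound 4 (0.17 log units; within the scatter). Read on two cores, the change leaves the number within the scatter each time, and the two readings cannot be told apart: the same change on two cores in this assay, a 1.5-fold higher number (0.18 log units; within the scatter) from compound 1 to compound 2 and a 1.5-fold lower number (0.17 log units; within the scatter) from compound 3 to compound 4, 2.3-fold (0.36 log units) apart, within the scatter of two such steps. Among the compounds shown here, a different change, methyl in place of hydrogen on a saturated chain carbon bound to two saturated chain carbons, is also read here for the first time, and it too stays within the scatter: a 1.2-fold higher number from compound 1 to compound 4 (0.07 log units; within the scatter).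

The compounds shown carry only saturated hydrocarbon chains at these places. From the compounds shown here alone, whether an amine or a carboxylic acid on this chain, or a chain longer than that of compound 2, would move the number beyond the scatter stays open.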